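Two inactive anilides and a dibromophenyl analogue

A few compounds are considered here, and "the series" means these few. Any claim that something is new, unique, unknown or untested is made for them only; others in the source may bear on it.

The shared core is shown by compound 1 `CC(C)Oc1ccc(NC(=O)CSc2nnc(Cc3nn(C)c(=O)c4ccccc34)n2C)cc1`, and compound 2 `COc1ccc(NC(=O)CSc2nnc(Cc3nn(C)c(=O)c4ccccc34)n2C)cc1` carries a different group on the anilide ring. In an assay on isolated protein (Mus musculus) for inhibition of IL15-IL15 receptor (Homo sapiens), read by resazurin assay, with stated times of 30 min and 2.5 days (on this read-out higher numbers stand for weaker inhibition and lower numbers for stronger inhibition), compound 1 reaches only a limit of > 30000 nM. Compound 2 in this assay is reported as "not active" (no number reported), with no number given. Compound 2 thus stands where this assay no longer resolves a value, and compound 1 sits at the limit of > 30000 nM in this assay, at which 1 of the 2 values shown sits. Compound 3 `Cn1c(Cc2nn(C)c(=O)c3ccccc23)nnc1SCC(=O)Nc1ccc(Br)cc1Br` has not been measured yet. It differs from compound 2 by 2,4-dibromophenyl in place of 4-methoxyphenyl on an amide-type nitrogen. Going by the values given here, no step between measured compounds is available, so the size of the change from compound 2 to compound 3 cannot be read from data; both measured compounds sit at or beyond the resolvable range, and no change beyond the scatter is expected in either direction. Compound 3 is expected to give about 30000 nM in this assay, within a range of 5000 nM to 100000 nM, and most likely again only a limit.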

Compound 3, half-maximal inhibitory concentration: > 30000 nM
Compound 3 ended at the assay's limit; the forecaster's own chance of this, stated with the estimate: 80%; the middle value lies on the limit itself.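

In this assay compound 3 gives > 30000 nM, which is a limit of the assay. Going by these compounds alone, compound 1 also stands at a limit and compound 2 has no number, so no step among the three can be read. As far as these compounds go, whether 2,4-dibromophenyl, 4-methoxyphenyl and 4-isopropoxyphenyl differ at all in this assay stays open.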